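Removing the hydroxymethyl from the dioxolane of compound 3

The source may hold more compounds than are shown below. What is called first, only, known or untested is meant among the compounds shown, and "the series" means these compounds.

Measured in a functional assay on HCT-116 cells (Homo sapiens) for cytotoxicity, read by MTT assay, with a stated time of 72 h; on this read-out lower numbers stand for stronger inhibition and higher numbers for weaker inhibition
- compound 1 `O=C1c2c[n+]([O-])c3ccccc3c2C(=O)c2c1c1ccccc1n2Cc1cn([C@@H]2C[C@H](O)[C@@H](CO)O2)nn1` gives 50 nM
- compound 2 `O=C1c2c[n+]([O-])c3ccccc3c2C(=O)c2c1c1ccccc1n2Cc1cn(CC(O)CO)nn1` gives 250 nM
- compound 3 `CC1(C)O[C@@H](CO)[C@H](Cn2cc(Cn3c4c(c5ccccc53)C(=O)c3c[n+]([O-])c5ccccc5c3C4=O)nn2)O1` gives 130 nM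

Among the measured compounds shown here, compound 3 stands clearly apart from only one neighbour (a 2.6-fold higher number from compound 1 to compound 3 (0.41 log units; beyond the scatter)) and not from the other (a 1.9-fold lower number from compound 2 to compound 3 (0.28 log units; within the scatter)). Compound 4 `CC1(C)OC[C@@H](Cn2cc(Cn3c4c(c5ccccc53)C(=O)c3c[n+]([O-])c5ccccc5c3C4=O)nn2)O1` carries 2,2-dimethyl-1,3-dioxolan-4-yl in place of 5-(hydroxymethyl)-2,2-dimethyl-1,3-dioxolan-4-yl on a saturated chain carbon bound to an aromatic nitrogen. For the measured compounds named here, no measured step removes this group alone. The closest change, at the same place, stayed within the scatter (a 1.9-fold lower number from compound 2 to compound 3 (0.28 log units; within the scatter)), and the largest step was modest (a 5.0-fold higher number from compound 1 to compound 2 (0.70 log units; beyond the scatter)). A small expected step, not beyond the scatter, is therefore estimated in this assay (a 1.2-fold higher number from compound 3 to compound 4 (0.09 log units; within the scatter)). The estimate for compound 4 is 160 nM (expected range 70 nM to 360 nM).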

Compound 4, half-maximal inhibitory concentration: 340 nM
For compound 4 the middle estimate is 2.1-fold (0.33 log units) below the measured one, within the range that was stated.
By their numbers in this assay, from the lowest: compound 1; then compounds 3, 2 and 4 (each within the scatter of the next, the first and the last beyond it).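

In this assay, removing the hydroxymethyl from the dioxolane is a step beyond the scatter (a 2.6-fold higher number from compound 3 to compound 4 (0.42 log units; beyond the scatter)), so this one group counts at this position, although compound 4 stays within the scatter of the 1,2-dihydroxyethyl compound (a 1.4-fold higher number from compound 2 to compound 4 (0.13 log units; within the scatter)). The gap to the 4-hydroxy-5-(hydroxymethyl)oxolan-2-yl of compound 1 becomes the largest step in the series (a 6.8-fold higher number from compound 1 to compound 4 (0.83 log units; beyond the scatter)). No available evidence bears on this result.

Going by these compounds, whether the hydroxyl itself matters remains open. A methoxymethyl or aminomethyl group on the dioxolane would test this.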